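A few compounds are considered here, and "the series" means these few. Any claim that something is new, unique, unknown or untested is made for them only; others in the source may bear on it.

Compound 1 `COc1cccc(Cc2cc(C(C)C)nn(CC(=O)Nc3ccc(Br)cc3)c2=O)c1` gives 17400 nM in an assay on HL-60 cells for agonist activity at N-formyl peptide receptor 3 (Homo sapiens), read by calcium flux; a lower number here means that less compound is needed, a higher number that more compound is needed for the effect.
Compound 2 `COc1ccc(Cc2cc(-c3ccc(C)cc3)nn(CC(=O)Nc3ccc(Br)cc3)c2=O)cc1` gives > 50000 nM in this assay, and this is a limit of the assay rather than a number.
Compound 3 `Cc1cc(Cc2cccc(Br)c2)c(=O)n(CC(=O)Nc2ccc(Br)cc2)n1` gives > 50000 nM in this assay, which is again a limit of the assay rather than a number.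

Compound 3 therefore stands at the limit of > 50000 nM in this assay, at which 2 of the 3 values shown sit. Its value is not a number, so the only thing that can be said is that compound 1 gives a measurable number while compound 3 does not; no size of gap between them can be read.

Compound 4 `Cc1cc(Cc2cccc3ccccc23)c(=O)n(CC(=O)Nc2ccc(Br)cc2)n1` differs from compound 3 in one place: naphthalen-1-yl in place of 3-bromophenyl on a saturated chain carbon bound to an aromatic carbon. Among the measured compounds shown here, no pair of measured compounds that differ in one place is available here, so no measured step tells how large such a change might be in this assay. Because compound 3 sits at the limit > 50000 nM, the step to compound 4 can only be no change beyond the scatter, or a move toward a measurable number; a move the other way cannot be seen.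

The expectation for compound 4 is therefore a cautious one, a step of an at least 1.4-fold lower number from compound 3 to compound 4 (0.15 log units; that floor lies within the scatter) being estimated. Compound 4 is expected to give about 35000 nM, within a range from 6000 nM to 60000 nM.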

Compound 4, half-maximal effective concentration: > 50000 nM
Compound 4: a limit, no number; the forecaster's own chance of this, stated with the estimate: 55%; middle value at least 1.4-fold (0.15 log units) from the limit.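

In this assay compound 4 gives > 50000 nM, which is a limit of the assay and not a number. Compound 3 sits at the same limit, so no step between compound 3 and compound 4 can be read: the limit of > 50000 nM in this assay, at which 3 of the 4 values shown sit.

The compounds shown leave open whether naphthalen-1-yl in place of 3-bromophenyl changes the effect at all.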